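Methoxy for methyl on the isoxazolidine aryl: lipophilicity expectation

This account rests on a few compounds, and the source may have more. Where it says the series, first, only, none or still open, it means among the compounds named here.

Measured so far:
compound 1, `Cc1ccc(C2=NO[C@]3(C2)C(=O)O[C@@H]2[C@H]3CC[C@H](C)[C@]3(O)C=CC(=O)[C@@]23C)cc1` — 1.86
compound 2, `Cc1ccc(C2C[C@@]3(ON2c2ccccc2)C(=O)O[C@@H]2[C@H]3CC[C@H](C)[C@]3(O)C=CC(=O)[C@@]23C)cc1` — 3.64

Of the compounds shown here, two have been measured in a physicochemical assay for lipophilicity; on this read-out higher numbers stand for higher lipophilicity and lower numbers for lower lipophilicity. Compound 1 gives 1.86 there, and compound 2 gives 3.64. On these two numbers compound 2 stands highest; its nearest neighbour is compound 1, which lies lower by a gap beyond the usual scatter of the measurement. Among the compounds with values here, no step between two measured compounds that differ in a single place is available, so the two values can only be read side by side.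

The next compound, compound 3, `COc1cccc(C2C[C@@]3(ON2c2ccccc2)C(=O)O[C@@H]2[C@H]3CC[C@H](C)[C@]3(O)C=CC(=O)[C@@]23C)c1`, differs from compound 2 in one place: 3-methoxyphenyl in place of 4-methylphenyl on a saturated ring carbon

For this change a modest step downward in this assay is expected, smaller than the gap between compound 1 and compound 2 but likely beyond the scatter. The step from compound 2 to compound 3 is estimated as a number 0.54 log units lower from compound 2 to compound 3 (beyond the scatter). Compound 3 is therefore expected to give about 3.1, with a range from 2.7 to 3.5.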

Compound 3, partition coefficient: 3.25
The estimate for compound 3 lay 0.15 log units below the measured number; the measured number falls inside the stated range.
By their numbers in this assay, from the lowest: compound 1; then compound 3; then compound 2.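

Within the data shown here, this is the first step that can be read at a single place, and it shows that the aryl group on the saturated ring carbon, next to the ring nitrogen, is not a silent position in this assay. Replacing 4-methylphenyl with 3-methoxyphenyl gives a number 0.39 log units lower from compound 2 to compound 3 (beyond the scatter), a modest move, with the rest of the compound unchanged and the entering group carrying a hydrogen-bond acceptor that the leaving group lacks. Nothing at hand accounts for the size or direction of this step.

The two group names differ both in the substituent and in its number on the phenyl ring, so this single step cannot divide its size between those two differences. It also leaves open how this position would respond to a group of another kind on that phenyl ring, such as an amine or a carboxylic acid, and whether the same exchange would give a step of similar size on the core of compound 1.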